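Swapping fluoro for methyl on the phenoxy ring

The source may hold more compounds than are shown below. What is called first, only, known or untested is meant among the compounds shown, and "the series" means these compounds.

Measured compounds:
compound 1, `Cc1nn(C)c(Oc2ccc(F)cc2)c1/C=N\OCc1c(Cl)c(-c2ccc(F)cc2)nn1C`, 7080 nM
compound 2, `Cc1nn(C)c(Oc2ccc(OC(F)(F)F)cc2)c1/C=N\OCc1c(Cl)c(-c2ccc(F)cc2)nn1C`, 2970 nM
compound 3, `Cc1nn(C)c(Oc2ccc(F)cc2)c1/C=N\OCc1c(Cl)c(-c2ccc(Cl)cc2)nn1C`, 4430 nM

All three were tested in a functional assay on SGC-7901 cells (Homo sapiens) for antiproliferative activity, read by MTT assay, with a stated time of 72 h; a higher number here means a weaker inhibitor, a lower number a stronger inhibitor. Compound 3 has the second highest of the three numbers; its nearest neighbour is compound 2, whose number is within the usual scatter of it, and compound 1 also lies within that scatter. So the three measured compounds cannot be ranked against one another with confidence.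

Compound 4, `Cc1ccc(Oc2c(/C=N\OCc3c(Cl)c(-c4ccc(Cl)cc4)nn3C)c(C)nn2C)cc1`, differs from compound 3 in one place: methyl in place of fluoro on an aromatic carbon. The change sits on an aromatic carbon of a six-membered aromatic ring of carbon only, para to a large group, turning a 4-fluorophenoxy into a 4-methylphenoxy.

Among the measured compounds shown here, one measured step touches the same position: a 2.4-fold lower number from compound 1 to compound 2 (0.38 log units; beyond the scatter), where a larger group also replaced fluoro. The other step, a 1.6-fold lower number from compound 1 to compound 3 (0.20 log units; within the scatter), changed fluoro on the other aromatic ring and stayed within the scatter. Neither involves methyl, so the bearing is indirect. A small lowering of the number is therefore expected, most likely within the scatter, and compound 4 is estimated at 3500 nM, with a range from 1500 nM to 8000 nM. This expectation amounts to a 1.3-fold lower number from compound 3 to compound 4 (0.10 log units; within the scatter).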

Compound 4, half-maximal inhibitory concentration: 3730 nM
Beside the measured number, compound 4's estimate is 1.1-fold (0.03 log units) below it; low and high end bracket the measured number.
By their numbers in this assay, from the lowest: compounds 2, 4, 3 and 1 (each within the scatter of the next, the first and the last beyond it).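

In this assay, the new result is a 1.2-fold lower number from compound 3 to compound 4 (0.07 log units; within the scatter), so at this position on the phenoxy ring, a methyl group and a fluoro group cannot be told apart. Before this, the only change measured at this position was trifluoromethoxy in place of fluoro, a 2.4-fold lower number from compound 1 to compound 2 (0.38 log units; beyond the scatter), and that step had fluoro on the other aromatic ring, whereas compound 3 and compound 4 carry chloro there; the new step shows that replacing fluoro here does not always move the number beyond the scatter, though its different group and different partner ring keep the two steps from being a clean comparison. Nothing measured here speaks to the reason for this result.

Going by these compounds, it remains open whether trifluoromethoxy would give a step of similar size with chloro on the other aromatic ring, which would separate the effect of the group from that of its partner ring. Also open, on these data alone, is how an amine, a carboxylic acid or a longer chain such as butyl at this position would read in this assay.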